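Changing the Side Chain on an Amide Nitrogen

This account rests on a few compounds, and the source may have more. Where it says the series, first, only, none or still open, it means among the compounds named here.

Compound 1 `CCn1c(C(=O)NCCNC(=O)OC(C)(C)C)ccc1C(CC)(CC)c1ccc(OCS(=O)(=O)c2ccccc2)c(C)c1` gives > 50000 nM as a limit, not a number
Compound 2 `CCn1c(C(=O)N[C@H](C)CO)ccc1C(CC)(CC)c1ccc(OCS(=O)(=O)c2ccccc2)c(C)c1` gives 7790 nM as a measured number

For the measured compounds named here, in a functional assay on PC-3 cells (Homo sapiens) for antiproliferative activity, read by MTT assay, with a stated time of 24 h (a higher number here means a weaker inhibitor, a lower number a stronger inhibitor), compound 2 at 7790 nM holds the only true number so far. Compound 1 offers only a limit, as the limit of > 50000 nM in this assay, at which 1 of the 2 values shown sits, records. Going by the values given here, the one measured step, an at least 6.4-fold lower number from compound 1 to compound 2 (0.80 log units; beyond the scatter), put 1-(hydroxymethyl)ethyl in place of 2-((tert-butoxycarbonyl)amino)ethyl on an amide-type nitrogen. Compound 3 `CCn1c(C(=O)N[C@H](CO)CCO)ccc1C(CC)(CC)c1ccc(OCS(=O)(=O)c2ccccc2)c(C)c1` changes that same place again: 3-hydroxy-1-(hydroxymethyl)propyl in place of 1-(hydroxymethyl)ethyl on an amide-type nitrogen brings in 3-hydroxy-1-(hydroxymethyl)propyl in place of 1-(hydroxymethyl)ethyl. The step to compound 2 shows that this place can matter, but it involved a different group and sets no direction here. No change beyond the scatter is therefore expected in this assay, and the estimated step is a 1.3-fold higher number from compound 2 to compound 3 (0.11 log units; within the scatter). For compound 3 the estimated value is 10000 nM, with an expected range of 3000 nM to 35000 nM.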

Compound 3, half-maximal inhibitory concentration: 12100 nM
The estimate for compound 3 lay 1.2-fold (0.08 log units) below the measured number; the range from low to high includes it.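

In this assay, swapping 1-(hydroxymethyl)ethyl for 3-hydroxy-1-(hydroxymethyl)propyl on the amide-type nitrogen gives a 1.6-fold higher number from compound 2 to compound 3 (0.19 log units; within the scatter), so the larger hydroxy-bearing side chain cannot be told apart from the smaller one here. Replacing 2-((tert-butoxycarbonyl)amino)ethyl with the new group gives an at least 4.1-fold lower number from compound 1 to compound 3 (0.61 log units; beyond the scatter), which means that the gain seen earlier is no longer tied to a single side chain. Compound 1 still has a limit and not a true number: the limit of > 50000 nM in this assay, at which 1 of the 3 values shown sits.

The compounds shown leave open whether the hydroxy groups themselves matter, since every measured number here comes from a side chain carrying at least one. A plain propyl chain, a free amine or a carboxylic acid at this place would help to settle that, as would the opposite stereocentre in compound 2.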